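Piperidine substituent variation on the shared amide core

A few compounds are considered here, and "the series" means these few. Any claim that something is new, unique, unknown or untested is made for them only; others in the source may bear on it.

compound 1 `CC(C(=O)NCc1ccc(C(F)(F)F)nc1NCc1ccccc1)c1ccc(NS(C)(=O)=O)c(F)c1`: 203 nM
compound 2 `CC(C(=O)NCc1ccc(C(F)(F)F)nc1N1CCC(C(F)(F)F)CC1)c1ccc(NS(C)(=O)=O)c(F)c1`: 31 nM
compound 3 `CC(=O)OC1CCN(c2nc(C(F)(F)F)ccc2CNC(=O)C(C)c2ccc(NS(C)(=O)=O)c(F)c2)CC1`: 139 nM

All numbers come from a functional assay on CHO-K1 cells for antagonist activity at transient receptor potential cation channel subfamily V member 1 (Homo sapiens), read by FLIPR; a higher number here means a weaker inhibitor, a lower number a stronger inhibitor. Compound 3 stands second highest of the three: the step of a 1.5-fold lower number from compound 1 to compound 3 (0.16 log units; within the scatter) lies within the scatter, while a 4.5-fold higher number from compound 2 to compound 3 (0.65 log units; beyond the scatter) lies beyond it. Compound 4 `CC(C(=O)NCc1ccc(C(F)(F)F)nc1N1CCC(CN(C)C)CC1)c1ccc(NS(C)(=O)=O)c(F)c1` is the next variant: (dimethylamino)methyl in place of acetoxy on a saturated ring carbon. For the measured compounds named here, the only measured step at this saturated ring carbon is a 4.5-fold higher number from compound 2 to compound 3 (0.65 log units; beyond the scatter), which shows the group there can move the number modestly; a 6.5-fold lower number from compound 1 to compound 2 (0.82 log units; beyond the scatter) and a 1.5-fold lower number from compound 1 to compound 3 (0.16 log units; within the scatter) show the piperidine variants spanning a similar span. Going by the values given here, no measured pair exchanges acetoxy for (dimethylamino)methyl, so the direction is open. Compound 4 is therefore expected to show a 1.4-fold lower number from compound 3 to compound 4 (0.14 log units; within the scatter), at most a modest step, probably toward a lower number. The estimate for compound 4 is 100 nM, between 30 nM and 400 nM.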

Compound 4, half-maximal inhibitory concentration: 426 nM
Estimate against measurement, compound 4: 4.3-fold (0.63 log units) below; the whole stated range lies below it.
By their numbers in this assay, from the lowest: compound 2; then compounds 3 and 1 (each within the scatter of the next); then compound 4.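

At this saturated ring carbon, (dimethylamino)methyl gives the largest step seen so far (a 14-fold higher number from compound 2 to compound 4 (1.14 log units; beyond the scatter)) and also stands above acetoxy (a 3.1-fold higher number from compound 3 to compound 4 (0.49 log units; beyond the scatter)), so the three groups now read trifluoromethyl, acetoxy, (dimethylamino)methyl from lowest number to highest. A 4-substituted piperidin-1-yl in place of benzylamino therefore does not always hold the number level or lower (a 2.1-fold higher number from compound 1 to compound 4 (0.32 log units; beyond the scatter)). Going by these compounds, whether a primary amine, a carboxylic acid or a longer chain at this carbon would come closer to trifluoromethyl stays open. No evidence at hand gives a cause for these steps.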